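Replacing the methoxynaphthyl group of compound 1 with 2-phenylethenyl

The source may report more compounds than this note shows. Statements on the series, on what has been measured and on what is new or still open speak of the compounds shown alone.

Compound 1 `COc1cc(N2C(N)=C(C#N)C(c3ccc(OC)c4ccccc34)C3=C2CC(C)(C)CC3=O)cc(OC)c1OC` gives 40% in a functional assay on Ehrlich cells (Mus musculus) for cytotoxicity, tested at 100 ug/mL (a higher number here means a stronger effect of the compound at the concentration tested, a lower number a weaker effect), the lowest of the three measured numbers. Compound 2 `COc1cc(N2C(N)=C(C#N)C(c3ccc(O)cc3)C3=C2CC(C)(C)CC3=O)cc(OC)c1OC` gives 100% in this assay, and compound 3 `COc1cc(N2C(N)=C(C#N)C(c3ccc(C)cc3)C3=C2CC(C)(C)CC3=O)cc(OC)c1OC` gives 90%. Both measured exchanges of the 4-methoxynaphthalen-1-yl group raised the read-out strongly: a number 60 percentage points higher from compound 1 to compound 2 (beyond the scatter) and a number 50 percentage points higher from compound 1 to compound 3 (beyond the scatter). Between the two replacements themselves a number 10 percentage points lower from compound 2 to compound 3 (within the scatter), so the gain does not depend on which of them enters. Compound 4 `COc1cc(N2C(N)=C(C#N)C(/C=C/c3ccccc3)C3=C2CC(C)(C)CC3=O)cc(OC)c1OC` differs from compound 1 in the same position: 2-phenylethenyl in place of 4-methoxynaphthalen-1-yl on a saturated ring carbon. Because a number 60 percentage points higher from compound 1 to compound 2 (beyond the scatter) and a number 50 percentage points higher from compound 1 to compound 3 (beyond the scatter) both point upward, a large rise is expected here too, a number 40 percentage points higher from compound 1 to compound 4 (beyond the scatter). Compound 4 is thus estimated at 80%, with a range from 50% to 100%.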

Compound 4, a percentage reported as activity, at one concentration (the size of the read-out at that concentration, not a potency): 40%
Compound 4: the middle estimate sits 40 percentage points above what was measured; the whole stated range lies above it.
By their numbers in this assay, from the lowest: compounds 1 and 4 (each within the scatter of the next); then compounds 3 and 2 (each within the scatter of the next).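

In this assay the 2-phenylethenyl group gives no gain over 4-methoxynaphthalen-1-yl, with no change at the digits printed from compound 1 to compound 4 (within the scatter) on this saturated ring carbon, and it falls short of both other replacements, with a number 50 percentage points lower from compound 3 to compound 4 (beyond the scatter) and a number 60 percentage points lower from compound 2 to compound 4 (beyond the scatter) in the same place. Having one aromatic ring of carbon only instead of two therefore does not by itself bring the rise. Nothing measured here gives a reason for this.

From the compounds shown here alone, whether the double bond outside aromatic rings is what counts remains open. A 2-phenylethyl group on this carbon would address that question.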